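The compounds below may be only part of what the source reports. "The series", "measured", "known", "first", "only" and "open" are said of these compounds alone.

Measured so far in an ADME assay on Raji cells (Homo sapiens) for cytotoxicity, read by CellTiter-Glo and resazurin assay, with a stated time of 72 h; a higher number here means that more compound is needed for the effect, a lower number that less compound is needed:
compound 1 `CC(=O)Nc1cccc(-c2ccc(C(=O)N(Cc3cccc(OCCCCCC(=O)O)c3)C(C)C)cc2)c1`, > 26000 nM
compound 2 `CCOC(=O)CCCCCOc1cccc(CN(C(=O)c2ccc(-c3cccnc3)cc2)C(C)C)c1`, > 26000 nM
compound 3 `CCOC(=O)CCCCCOc1cccc(CN(C(=O)c2ccc(-c3cn(S(=O)(=O)c4ccccc4)c4ccccc34)cc2)C(C)C)c1`, > 26000 nM

Compound 1 reaches only the limit of this assay, > 26000 nM, which is not a number. For compound 2 the result is likewise a limit, > 26000 nM. Compound 3 also stops at a limit, > 26000 nM. All three results meet (the limit of > 26000 nM in this assay, at which 3 of the 3 values shown sit), so no ordering among them can be read from these values, and compound 2 stands at the same limit as the other two.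

Compound 4 `CCOC(=O)CCCCCOc1cccc(CN(C(=O)c2ccc(-c3cccc(O)c3)cc2)C(C)C)c1` is not yet measured. It differs from compound 2 in one place: 3-hydroxyphenyl in place of pyridin-3-yl on an aromatic carbon. Within the data shown here, no measured pair here shares this change, so nothing shows its effect on cytotoxicity. Given that compound 2 sits at > 26000 nM, the step from compound 2 to compound 4 is expected to be a step that the limit leaves unreadable from compound 2 to compound 4, within the scatter. Compound 4 is therefore expected to give about 40000 nM, in the range 15000 nM to 120000 nM, most likely reported again as a limit.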

Compound 4, half-maximal effective concentration: > 26000 nM
Compound 4: no number, only a limit; the forecaster's own chance of this, stated with the estimate: 80%; the middle value does not contradict the limit.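

Compound 2 and compound 4 both end at a limit rather than a number, so no step can be read between them: the limit of > 26000 nM in this assay, at which 4 of the 4 values shown sit.

The compounds shown leave open how 3-hydroxyphenyl and pyridin-3-yl compare in this assay, and which change to these structures, if any, would give a measurable value.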